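The source may report more compounds than this note shows. Statements on the series, on what has been measured and on what is new or still open speak of the compounds shown alone.

Measured compounds in an assay on HeLa cells for displacement of a labelled ligand from adenosine receptor A3 (Homo sapiens), with a stated time of 180 min, tested at 1 uM; on this read-out higher numbers stand for more inhibition at the one concentration tested (going by the name of the read-out) and lower numbers for less inhibition:

Compound 1 `CCOC(=O)C1=C(C)N/C(=N\C#N)NC1c1cccs1` gives 3%
Compound 2 `CCOC(=O)C1=C(C)N/C(=N\C#N)NC1c1ccoc1` gives 14%
Compound 3 `CC1=C(C(=O)OC(C)C)C(c2cccs2)N/C(=N/C#N)N1` gives 27%

Compound 3 stands highest of the three in this assay, and both of its gaps to the others are beyond the scatter. Compound 4 `CC1=C(C(=O)OC(C)C)C(c2ccoc2)N/C(=N/C#N)N1` has not yet been measured in this assay.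

The change that leads from compound 3 to compound 4 is furan-3-yl in place of thiophen-2-yl on a saturated ring carbon. The same structural change has already been made once among measured compounds, from compound 1 to compound 2, where it is furan-3-yl in place of thiophen-2-yl on a saturated ring carbon and gave a number 11 percentage points higher from compound 1 to compound 2 (beyond the scatter) in this assay.

The two cores on which this change is made differ by methyl in place of hydrogen on a saturated chain carbon bound to an oxygen next to a carbonyl group and a saturated chain carbon, and the step that this core change produced in this assay was a number 24 percentage points higher from compound 1 to compound 3 (beyond the scatter). The place of the exchange is also not identical in wording. In compound 1 the saturated ring carbon sits next to the ring atom that bears an ethoxycarbonyl group (5 heavy atoms), while in compound 3 it sits next to the ring atom that bears an isopropoxycarbonyl group (6 heavy atoms). The exchange is therefore the same kind of change, not the same change.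

Going by the values given here, with only one earlier example of this change, the expectation for compound 4 rests on it alone: a step of about the size seen from compound 1 to compound 2 is expected, which would put compound 4 in this assay around 37%, expected to fall between 22% and 52%, and the expected step from compound 3 to compound 4 is a number 10 percentage points higher from compound 3 to compound 4 (within the scatter).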

Compound 4, a percentage reported as inhibition, at one concentration (the size of the read-out at that concentration, not a potency): 41%
Estimate against measurement, compound 4: 4 percentage points below, and the stated range covers the measured number.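

In this assay, furan-3-yl in place of thiophen-2-yl on the core carrying the isopropoxycarbonyl group gave a number 14 percentage points higher from compound 3 to compound 4 (beyond the scatter), and this agrees with the step seen for the same exchange on the core carrying the ethoxycarbonyl group: the same change on two cores in this assay, a number 11 percentage points higher (beyond the scatter) from compound 1 to compound 2 and a number 14 percentage points higher (beyond the scatter) from compound 3 to compound 4, 3 percentage points apart, within the scatter of two such steps

The reverse view of the square tells the same story, since isopropoxycarbonyl in place of ethoxycarbonyl with furan-3-yl on the ring gave a number 27 percentage points higher from compound 2 to compound 4 (beyond the scatter), which agrees with the step seen with thiophen-2-yl on the ring: the same change on two cores in this assay, a number 24 percentage points higher (beyond the scatter) from compound 1 to compound 3 and a number 27 percentage points higher (beyond the scatter) from compound 2 to compound 4, 3 percentage points apart, within the scatter of two such steps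

Across these four compounds, then, each change kept its size on the other core and the two simply added up, but this rests on a single square of compounds, read at one concentration, and it shows neither a potency nor why the numbers rise.

The exchange alters both the ring's hetero atom and its point of attachment, so thiophen-3-yl or furan-2-yl on the same saturated ring carbon would be needed to tell these two apart. On these data alone, it also remains open whether the additive behaviour would hold for a phenyl ring in that place, or for a tert-butoxycarbonyl group or a carboxylic acid in place of the ester.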